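The source may report more compounds than this note shows. Statements on the series, on what has been measured and on what is new or still open speak of the compounds shown alone.

Of the compounds shown here, three have been measured in a functional assay on the whole organism (Tail, strain ICR) with Mus musculus as the target, in the tail flick test, with a stated time of 150 min, at a dose of 25 umol/kg by the oral route; a higher number here means a stronger effect of the compound at the dose given, a lower number a weaker effect. Compound 1, `NC(=O)CC[C@H](NC(=O)CN(c1ncnc2c1ncn2C1CCCCO1)C1CC1)C(=O)OCc1ccccc1`, gives 10.7%, and compound 2, `O=C(CN(c1ncnc2c1ncn2C1CCCCO1)C1CC1)N[C@@H](CCC(=O)OCc1ccccc1)C(=O)OCc1ccccc1`, gives 14.1%. Among the compounds with values here, the only step between two measured compounds that differ in one place is a number 3.4 percentage points higher from compound 1 to compound 2 (within the scatter). Compound 3, `CC[C@H](C)[C@H](NC(=O)CN(c1nc(Cl)nc2[nH]cnc12)C1CC1)C(=O)O`, gives 6.71%; this is the lowest of the three numbers, but its gap to compound 1 and its gap to compound 2 both lie within the scatter, so the three compounds cannot be told apart on these numbers.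

Compound 4, `C[C@@H](O)[C@H](NC(=O)CN(c1nc(Cl)nc2[nH]cnc12)C1CC1)C(=O)O`, differs from compound 3 by hydroxy in place of ethyl on a saturated chain carbon bound to two saturated chain carbons. Within the data shown here, no measured step involves this kind of change, so the one known step, which concerns a different part of the molecule and was itself within the scatter, gives no direct guidance. With every number seen so far low and close together, the expectation is that compound 4 stays near compound 3, with a step of a number 1.3 percentage points higher from compound 3 to compound 4 (within the scatter) that does not go beyond the scatter. The estimate for compound 4 in this assay is therefore 8%, within a range from 0% to 20%.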

Compound 4, a percentage reported as activity, at one dose (the size of the read-out at that dose, not a potency): 24%
Beside the measured number, compound 4's estimate is 16 percentage points below it; the measured number lies above the stated range.
By their numbers in this assay, from the lowest: compounds 3, 1, 2 and 4 (each within the scatter of the next, the first and the last beyond it).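

In this assay, within the data shown here, this saturated chain carbon, bound to two saturated chain carbons, is the first place where one change moves the read-out beyond the usual scatter: hydroxy in place of ethyl gives a number 17.3 percentage points higher from compound 3 to compound 4 (beyond the scatter), though the step is modest. Among these compounds, the only earlier step, on a carbonyl carbon, stayed within the scatter, so the result marks this position as one where the read-out responds to the group carried there. Nothing measured here explains why the number rises.

From the compounds shown here alone, whether the gain comes from the arrival of hydroxy or from the loss of ethyl stays open, and a methyl, a methoxy or an amine on the same carbon would help separate the two. Also open, going by these compounds, is whether the same swap would raise the number in a compound built around a different amino acid side chain.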